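A few compounds are considered here, and "the series" means these few. Any claim that something is new, unique, unknown or untested is made for them only; others in the source may bear on it.

Compound 2 `COCc1nc2nc(C)cc(Nc3ccc(C(F)(F)F)cc3)n2n1` is the starting point of this step. Among the compounds with values here, in a physicochemical assay for solubility, at pH 6.5 (on this read-out higher numbers stand for higher solubility and lower numbers for lower solubility), compound 2 gives 150000 nM, the highest of the three numbers measured so far. Compound 1 `COCc1nc2nc(C)cc(Nc3ccc(S(F)(F)(F)(F)F)cc3)n2n1` gives 63000 nM, and compound 3 `CCC(F)(F)c1nc2nc(C)cc(Nc3ccc(S(F)(F)(F)(F)F)cc3)n2n1` gives 15000 nM. The two measured steps are a 2.4-fold higher number from compound 1 to compound 2 (0.38 log units; beyond the scatter) and a 4.2-fold lower number from compound 1 to compound 3 (0.62 log units; beyond the scatter).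

Compound 4 `CCOc1nc2nc(C)cc(Nc3ccc(C(F)(F)F)cc3)n2n1` differs from compound 2 by ethoxy in place of methoxymethyl on an aromatic carbon. Within the data shown here, of the measured steps, only the one from compound 1 to compound 3 touches the same place on the shared core, where a 1,1-difluoropropyl replaced methoxymethyl, and it was a 4.2-fold lower number from compound 1 to compound 3 (0.62 log units; beyond the scatter). Among the measured compounds shown here, no measured step exchanges methoxymethyl for ethoxy, and the two groups carry the same atoms joined differently, so the guide is weak. Compound 4 is therefore expected to show a 1.3-fold lower number from compound 2 to compound 4 (0.10 log units; within the scatter), a step within the scatter or at most modest, and its number in this assay is estimated at 120000 nM, within a range from 50000 nM to 300000 nM.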

Compound 4, solubility: 19000 nM
Compound 4: middle estimate off by 6.3-fold (0.80 log units), on the high side, and the stated range ends above it.
By their numbers in this assay, from the lowest: compounds 3 and 4 (each within the scatter of the next); then compound 1; then compound 2.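

In this assay, this position proves sensitive even to a change that leaves the atoms the same: ethoxy in place of methoxymethyl gives a 7.9-fold lower number from compound 2 to compound 4 (0.90 log units; beyond the scatter), although both groups have the same heavy-atom count, hydrogen-bond donor and acceptor counts and no net charge. Within the data shown here, the only earlier step at this position, a 4.2-fold lower number from compound 1 to compound 3 (0.62 log units; beyond the scatter), brought in a different set of atoms on a different parent, so it could not show that rearranging the same atoms alone can move the number beyond the scatter. No measurement shown here accounts for this step.

On these data alone, it remains open whether ethoxy would lower the number in the same way on the core of compound 1. Also open, as far as these compounds go, is how an amine or a longer ether chain at this position would compare with methoxymethyl.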